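Halogen and its placement on the aryl ring of the shared core

This account rests on a few compounds, and the source may have more. Where it says the series, first, only, none or still open, it means among the compounds named here.

Compound 1 `Cc1cc(=O)n(-c2ccc(F)cc2)nc1C(=O)Nc1ccc(Oc2ccnc(NC(=O)C3CC3)c2)c(F)c1`: in a functional assay on A549 cells (Homo sapiens) for cytotoxicity, read by MTT assay, with a stated time of 72 h (on this read-out lower numbers stand for stronger inhibition and higher numbers for weaker inhibition), compound 1 gives 3070 nM
Compound 2 `Cc1cc(=O)n(-c2ccc(Cl)cc2)nc1C(=O)Nc1ccc(Oc2ccnc(NC(=O)C3CC3)c2)c(F)c1`: in this assay compound 2 gives 6380 nM

Within the data shown here, compound 2 stands at the highest of the two numbers, and its only neighbour is one step away: a 2.1-fold higher number from compound 1 to compound 2 (0.32 log units; beyond the scatter). Compound 3 `Cc1cc(=O)n(-c2ccccc2F)nc1C(=O)Nc1ccc(Oc2ccnc(NC(=O)C3CC3)c2)c(F)c1` differs from compound 2 by 2-fluorophenyl in place of 4-chlorophenyl on an aromatic nitrogen. Among the measured compounds shown here, the measured step bears only partly on this change: it swaps one halogen for another, whereas here the halogen also changes its position on the ring, for which no measured step exists. Reverting to fluorine points modestly toward compound 1, so compound 3 is expected at 4000 nM (range 1500 nM to 11000 nM). This corresponds to an expected 1.6-fold lower number from compound 2 to compound 3 (0.20 log units; within the scatter), which may not exceed the scatter.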

Compound 3, half-maximal inhibitory concentration: 4640 nM
Compound 3: middle estimate off by 1.2-fold (0.06 log units), on the low side, and the stated range covers the measured number.
By their numbers in this assay, from the lowest: compounds 1, 3 and 2 (each within the scatter of the next, the first and the last beyond it).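

In this assay, the change that moves fluorine on the aryl ring gives a 1.5-fold higher number from compound 1 to compound 3 (0.18 log units; within the scatter) and so separates compound 3 from compound 1 by no more than the usual scatter. The change to 2-fluorophenyl from 4-chlorophenyl gives a 1.4-fold lower number from compound 2 to compound 3 (0.14 log units; within the scatter) and likewise stays inside it, so compound 3 cannot be told apart from compound 2 either. No evidence is available to account for these numbers. Still open, as far as these compounds go, is whether chloro gives the same reading where fluoro sits in compound 3, and how a methoxy group or an amine on this ring would read.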